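Demethylation of a Fused Bicyclic Amino Alcohol Core

A few compounds are considered here, and "the series" means these few. Any claim that something is new, unique, unknown or untested is made for them only; others in the source may bear on it.

Compound 1 `CN1CC[C@@H]2CC[C@H](O)C[C@@H]21` and compound 2 `O[C@H]1CC[C@H]2CCN[C@H]2C1` share one core, while compound 3 `CN1CCC2=CC[C@H](O)C[C@@H]21` and compound 4 `O[C@H]1CC=C2CCN[C@H]2C1` share another; the difference between the two cores is not broken down here. In an assay on HEK293 cells for displacement of a labelled ligand from Neuronal acetylcholine receptor; alpha4/beta4 (Rattus norvegicus), with a stated time of 4 h (on this read-out lower numbers stand for stronger inhibition and higher numbers for weaker inhibition), compound 1 gives only a limit, > 300000 nM. In this assay compound 2 likewise gives only a limit, > 300000 nM. In this assay compound 3 also gives only a limit, > 300000 nM. The change hydrogen in place of methyl on an amine nitrogen in a ring produced a step that the two limits leave unreadable from compound 1 to compound 2. The same kind of change, (hydrogen in place of methyl on an amine nitrogen in a ring), is made from compound 3 to compound 4; the place differs in that for the first pair it is additionally described as two ring bonds from the ring atom that bears a fused ring. Because every measured value sits at the limit (the limit of > 300000 nM in this assay, at which 3 of the 3 values shown sit), the step is expected to be a number no higher from compound 3 to compound 4 (the limit leaves the size open). Compound 4 is expected to give 300000 nM in this assay, very probably again as a limit.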

Compound 4, inhibition constant: > 300000 nM
Compound 4: a limit, no number; the forecaster's own chance of this, stated with the estimate: 90%; the middle value sits exactly at the limit.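

Compound 3 and compound 4 both give only limits, so no step can be read between them. The compounds shown leave open how large any effect of hydrogen in place of methyl is on either core: the limit of > 300000 nM in this assay, at which 4 of the 4 values shown sit.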